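Ethyl ester series: nitro in place of chloro

The source may hold more compounds than are shown below. What is called first, only, known or untested is meant among the compounds shown, and "the series" means these compounds.

Measured in a functional assay on the whole organism (strain Sprague-Dawley) for inhibition, with Rattus norvegicus as the target, with a stated time of 10 min; on this read-out lower numbers stand for an effect already at smaller amounts and higher numbers for an effect only at larger amounts of compound:
- compound 1 `CCOc1ccc(Cl)cc1-c1ncc(C(=O)O)c(=O)[nH]1`: 0.5 mg/kg
- compound 2 `CCOC(=O)c1cnc(-c2ccc(C(F)(F)F)cc2)[nH]c1=O`: > 5 mg/kg (a limit of the assay)
- compound 3 `CCOC(=O)c1cnc(-c2cc(Cl)ccc2OCC)[nH]c1=O`: 0.5 mg/kg

Compound 3 stands at 0.5 mg/kg, level with compound 1. For compound 2 the read-out is only a limit: the limit of > 5 mg/kg in this assay, at which 1 of the 3 values shown sits.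

Compound 4 `CCOC(=O)c1cnc(-c2cc([N+](=O)[O-])ccc2OCC)[nH]c1=O` is compound 3 with nitro in place of chloro on an aromatic carbon, para to an ethoxy group: nitro in place of chloro on an aromatic carbon.

Among the compounds with values here, only one measured step is available, no change at the digits printed from compound 1 to compound 3 (within the scatter). Within the data shown here, it lies elsewhere in the molecule, and no measured step changes the chloro group, so it bears on this change only indirectly. The expectation therefore starts from compound 3 at 0.5 mg/kg, with no shift beyond the scatter expected in this assay and no direction favoured. The expected size is no change at the digits printed from compound 3 to compound 4 (within the scatter). The estimate for compound 4 is 0.5 mg/kg, with an expected range of 0.12 mg/kg to 2.5 mg/kg.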

Compound 4, dose for 50% inhibition: 5 mg/kg
Compound 4: the middle estimate sits 10-fold (1.00 log units) below what was measured; measured number above the stated range.
By their numbers in this assay, from the lowest: compounds 1 and 3 (each within the scatter of the next); then compound 4.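

Within the data shown here, this is the first measured change on this aromatic carbon, para to an ethoxy group, and the read-out responds: in this assay, nitro in place of chloro gives a 10-fold higher number from compound 3 to compound 4 (1.00 log units; beyond the scatter). The ethyl ester step elsewhere in the molecule gave no change at the digits printed from compound 1 to compound 3 (within the scatter), whereas this carbon does not accept every replacement, with chloro giving the smaller number of this one pair. Compound 2 remains a limit and not a number, and it sets no ceiling on this step: the limit of > 5 mg/kg in this assay, at which 1 of the 4 values shown sits.

From the compounds shown here alone, with a single replacement at this carbon, it stays open whether the higher number belongs to nitro itself or would follow from other groups in place of chloro, such as an amine, a nitrile or a methyl group. Going by these compounds, whether the same step holds with the free carboxylic acid of compound 1 also stays open.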